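The source may report more compounds than this note shows. Statements on the series, on what has been measured and on what is new or still open speak of the compounds shown alone.

Measured compounds:
compound 1 `CCCCCCCCCCCCN(C)C(=O)Cn1cc(Cc2cnc(=O)n(CC(=O)NC)c2)c(=O)nc1SCc1ccc(F)cc1` — 28%
compound 2 `CCCCCCCCCCCCN(C)C(=O)Cn1cc(Cc2cnc(=O)n(CC(=O)NCCO)c2)c(=O)nc1SCc1ccc(F)cc1` — 37%

In a functional assay on a cell-free system (plasma, Oryctolagus cuniculus) for inhibition of platelet-activating factor acetylhydrolase (Homo sapiens), tested at 100 nM (a lower number here means less inhibition, a higher number more inhibition at the concentration tested (going by the name of the read-out)), compound 1 gives 28%, and compound 2 gives 37%. Among the compounds with values here, compound 2 has the higher of the two numbers, but the only measured step, a number 9 percentage points higher from compound 1 to compound 2 (within the scatter), lies within the scatter, so the two compounds cannot be told apart on these numbers.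

Compound 3 `CCCCCCCCCCCCN(C)C(=O)Cn1cc(Cc2cnc(=O)n(CC(=O)N3CCOCC3)c2)c(=O)nc1SCc1ccc(F)cc1` differs from compound 2 in one place: morpholin-4-yl in place of (2-hydroxyethyl)amino on a carbonyl carbon. Within the data shown here, the one measured step concerns a different change, hydroxymethyl in place of hydrogen on a saturated chain carbon bound to an amide-type nitrogen, and does not bear on the exchange of the (2-hydroxyethyl)amino group for morpholin-4-yl. Among the measured compounds shown here, with no step to draw on, no change beyond the scatter is expected in this assay , and the estimated step is a number 4 percentage points lower from compound 2 to compound 3 (within the scatter). Compound 3 is therefore expected to give about 33% in this assay , with a range from 15% to 55%.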

Compound 3, a percentage reported as inhibition, at one concentration (the size of the read-out at that concentration, not a potency): 30%
The estimate for compound 3 lay 3 percentage points above the measured number; the range from low to high includes it.
By their numbers in this assay, from the lowest: compounds 1, 3 and 2 (each within the scatter of the next).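

In this assay, morpholin-4-yl in place of (2-hydroxyethyl)amino on the carbonyl carbon gives a number 7 percentage points lower from compound 2 to compound 3 (within the scatter), and morpholin-4-yl in place of methylamino gives a number 2 percentage points higher from compound 1 to compound 3 (within the scatter). Within the data shown here, this place in the structure therefore now carries a six-membered non-aromatic ring with 0 hydrogen-bond donors as well as two open-chain groups, and no step among the three compounds can be told from the scatter. Nothing measured here explains why the three numbers stay so close.

Still open, on these data alone, is whether a different group on this carbonyl carbon, such as a (2-aminoethyl)amino group with its terminal amine or a group ending in a carboxylic acid, would shift the number beyond the scatter. Since each number comes from a single concentration, any difference in potency among these three compounds also remains open.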